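Methyl on compound 2: expected effect on cytotoxicity

The compounds below may be only part of what the source reports. "The series", "measured", "known", "first", "only" and "open" are said of these compounds alone.

Within the data shown here, in a functional assay on A549 cells (Homo sapiens) for cytotoxicity, with a stated time of 48 h (a higher number here means a weaker inhibitor, a lower number a stronger inhibitor), compound 2 `C[S+]([O-])/C=C/c1cc(=O)c2ccccc2o1` gives 1900 nM, the lower of the two numbers so far, and compound 1 `CC(=O)Oc1ccc2oc(/C=C/[S+](C)[O-])cc(=O)c2c1` gives 4100 nM. Among the measured compounds shown here, the only measured step, a 2.2-fold lower number from compound 1 to compound 2 (0.33 log units; beyond the scatter), is modest and lies beyond the scatter. Compound 3 `Cc1cccc2c(=O)cc(/C=C/[S+](C)[O-])oc12` brings (methyl in place of hydrogen on an aromatic carbon), a methyl in place of hydrogen on an aromatic carbon. For the measured compounds named here, no measured step involves methyl, and the acetoxy step bears only loosely, so no step beyond the scatter is expected in this assay. The expected change is small, a 1.2-fold higher number from compound 2 to compound 3 (0.06 log units; within the scatter). For compound 3 the estimated value is 2200 nM, within an expected range of 900 nM to 5000 nM.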

Compound 3, half-maximal inhibitory concentration: 1700 nM
Beside the measured number, compound 3's estimate is 1.3-fold (0.11 log units) above it; the measured number falls inside the stated range.
By their numbers in this assay, from the lowest: compounds 3 and 2 (each within the scatter of the next); then compound 1.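

In this assay, methyl in place of hydrogen on this aromatic carbon, ortho to a fused ring and meta to a fused ring, gives a 1.1-fold lower number from compound 2 to compound 3 (0.05 log units; within the scatter). The position therefore accepts a methyl with no readable change in cytotoxicity, whereas the acetoxy step, a 2.2-fold lower number from compound 1 to compound 2 (0.33 log units; beyond the scatter), lies beyond the scatter. No available data account for this result.

Still open, going by these compounds, is whether a methoxy group, an amine or a longer chain on this same carbon would also stay within the scatter. Whether hydrogen and methyl behave alike at the other aromatic carbons of the shared core also remains unsettled.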